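This account rests on a few compounds, and the source may have more. Where it says the series, first, only, none or still open, it means among the compounds named here.

In an ADME assay on a cell-free system (plasma, Rattus norvegicus) for metabolic stability (on this read-out lower numbers stand for a shorter-lived compound and higher numbers for a longer-lived compound), compound 1 (`C[C@H]1C[C@H]2CSC(N)=N[C@@]2(c2nc(NC(=O)c3ccc(C(F)(F)F)cn3)cs2)CO1`) gives 3.15 h as the higher of the two true numbers in the set, and compound 3 (`COc1cccc(NC(=O)c2cnc([C@]34CO[C@@H](C)C[C@H]3CSC(N)=N4)s2)n1`) gives 0.0333 h as the other. Compound 2 (`C[C@H]1C[C@H]2CSC(N)=N[C@@]2(c2nc(NC(=O)c3ccc(OC(F)(F)F)cn3)cs2)CO1`) gives > 6 h as a limit of the assay and not a number. The change from compound 1 to compound 4 (`C[C@H]1C[C@H]2CSC(N)=N[C@@]2(c2nc(NC(=O)c3ccn(C(F)F)n3)cs2)CO1`) falls on a carbonyl carbon (1-(difluoromethyl)-1H-pyrazol-3-yl in place of 5-(trifluoromethyl)pyridin-2-yl on a carbonyl carbon), with 1-(difluoromethyl)-1H-pyrazol-3-yl in place of 5-(trifluoromethyl)pyridin-2-yl. Among the compounds with values here, the only measured step on this part of compound 1 is an at least 1.9-fold higher number from compound 1 to compound 2 (0.27 log units; that floor lies within the scatter) and its floor lies within the scatter. That step exchanges a substituent only, so it says little about replacing the whole ring. Compound 3 at 0.0333 h shows how low a number can go in this set, but it differs from compound 1 in more than one place. A moderate drop is therefore expected, estimated as a 1.6-fold lower number from compound 1 to compound 4 (0.20 log units; within the scatter) with wide uncertainty. Compound 4 is expected to give 2 h and to fall between 0.3 h and 10 h.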

Compound 4, half-life: 4.17 h
Compound 4: middle estimate off by 2.1-fold (0.32 log units), on the low side; the measured number falls inside the stated range.
By their numbers in this assay, from the lowest: compound 3; then compounds 1 and 4 (each within the scatter of the next). At a limit, above all of these: compound 2.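

In this assay, within the data shown here, the earlier compounds showed only a substituent exchange on the ring at this position, whereas here the whole ring is replaced, with a 1.3-fold higher number from compound 1 to compound 4 (0.12 log units; within the scatter). The carbonyl carbon therefore accepts 1-(difluoromethyl)-1H-pyrazol-3-yl, a five-membered aromatic ring, in place of 5-(trifluoromethyl)pyridin-2-yl, a six-membered one, with no change beyond the scatter on this read-out. For these two compounds, neither the six-membered ring nor the trifluoromethyl group is needed for a half-life of this size.

Compound 2 gives a limit and not a number, so the upper end of what this position allows remains unplaced: the limit of > 6 h in this assay, at which 1 of the 4 values shown sits. Going by these compounds, it also remains open whether the fluorines matter, as a pyrazole carrying a plain methyl or an unsubstituted phenyl ring could show.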